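Cytotoxicity at the assay limit across the benzylidene amide series

The compounds below may be only part of what the source reports. "The series", "measured", "known", "first", "only" and "open" are said of these compounds alone.

Compound 1 `O=C(NCC1CCCCC1)c1cccc(/C=C2\CC(=O)N(c3ccccc3)C2=O)c1` is assessed in an ADME assay on NCM460 cells (Homo sapiens) for cytotoxicity, read by MTT assay, with a stated time of 72 h; a higher number here means a weaker inhibitor, a lower number a stronger inhibitor. Compound 1 gives only a limit there, > 100000 nM. Compound 2 `CCCCCN1C(=O)C/C(=C\c2cccc(C(=O)Nc3cccc(F)c3)c2)C1=O` likewise gives only a limit, > 100000 nM. Compound 3 `O=C(Nc1ccc(Cl)cc1)c1cccc(/C=C2\CC(=O)N(Cc3ccccc3)C2=O)c1` also reaches only a limit, > 100000 nM. Among the compounds with values here, all three values sit at the limit of > 100000 nM in this assay, at which 3 of the 3 values shown sit, so no step between measured compounds can be read, and compound 1 stands where every other measured compound stands. Compound 4 `CSc1cccc(NC(=O)c2cccc(/C=C3\CC(=O)N(c4ccccc4)C3=O)c2)c1` differs from compound 1 in one place: 3-(methylsulfanyl)phenyl in place of cyclohexylmethyl on an amide-type nitrogen. With the shared core unchanged and every measured value at the limit, the step that the limit leaves unreadable from compound 1 to compound 4 is expected to be none beyond the scatter. Compound 4 is therefore estimated at 150000 nM, between 60000 nM and 400000 nM, most likely reported again as a limit.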

Compound 4, half-maximal inhibitory concentration: > 100000 nM
Compound 4: only a limit was reported; the forecaster's own chance of this, stated with the estimate: 80%; the middle value lies beyond the limit too.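

Compound 1 and compound 4 both give only a limit in this assay, so no new step can be read between them: the limit of > 100000 nM in this assay, at which 4 of the 4 values shown sit.

The compounds shown leave open at what concentration, if any, these compounds inhibit the cells, and whether the group on the amide-type nitrogen changes that.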